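Swapping a Ring Group for Dimethylamino

This account rests on a few compounds, and the source may have more. Where it says the series, first, only, none or still open, it means among the compounds named here.

Compound 1 `O=C(O)COc1cc(Cl)c(C(=O)Nc2cccc(-c3nc4ccccc4s3)c2)cc1[N+](=O)[O-]`: < 1 10^-6 cm/s (a limit, not a number)
Compound 2 `Cc1ccc(-c2nc3ccccc3s2)cc1NC(=O)c1cc([N+](=O)[O-])c(N2CCC(C(=O)O)CC2)cc1Cl`: 17 10^-6 cm/s

Among the compounds with values here, in an ADME assay for permeability, using PAMPA, at pH 7.4 (on this read-out higher numbers stand for higher permeability and lower numbers for lower permeability), compound 2 gives 17 10^-6 cm/s, the only true number so far. Compound 1 gives only a limit, < 1 10^-6 cm/s.

Compound 3 `Cc1ccc(-c2nc3ccccc3s2)cc1NC(=O)c1cc([N+](=O)[O-])c(N(C)C)cc1Cl` keeps the core of compound 2 and changes a single group: dimethylamino in place of 4-carboxypiperidin-1-yl on an aromatic carbon.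

Within the data shown here, no pair of measured compounds shows a change of this kind, so any expectation here is a loose one. A moderate rise in this assay is expected, though the result could also stay within the usual scatter. The expected step is a 1.5-fold higher number from compound 2 to compound 3 (0.17 log units; within the scatter). With a single true number to build on, the range is kept wide. The value expected for compound 3 is 25 10^-6 cm/s, within an estimated range of 6 10^-6 cm/s to 80 10^-6 cm/s.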

Compound 3, apparent permeability: < 1 10^-6 cm/s
Compound 3 gave a limit, no number; the forecaster's own chance of this, stated with the estimate: 10%; at least 25-fold (1.39 log units) between middle value and limit.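

Changing this one group, on the aromatic carbon ortho to a nitro group, gives an at least 17-fold lower number from compound 2 to compound 3 (1.23 log units; beyond the scatter) in this assay with the rest of the molecule unchanged. So at this position, 4-carboxypiperidin-1-yl and dimethylamino are not interchangeable, which the earlier compounds could not show. The value for compound 3 is a limit and not a true number, so the step has only a known minimum, and compound 3 joins a shared floor: the limit of < 1 10^-6 cm/s in this assay, at which 2 of the 3 values shown sit.

The change removes the ring and the carboxylic acid together, so the result cannot say which of the two matters here. A plain piperidin-1-yl group without the carboxylic acid, or an open-chain amine carrying a carboxylic acid at the end of a longer chain, would be needed to separate them.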